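Chloro-to-fluoro swap on the dicyano-free aromatic position, compound 4

A few compounds are considered here, and "the series" means these few. Any claim that something is new, unique, unknown or untested is made for them only; others in the source may bear on it.

Measured compounds:
- compound 1 `N#Cc1c(F)c(Cl)c2nc(N)nc(N)c2c1F`: 1.5 ug/mL
- compound 2 `N#Cc1c(F)c(F)c2nc(N)nc(N)c2c1F`: 105 ug/mL
- compound 3 `CCN(CC)c1c(C#N)c(F)c2c(N)nc(N)nc2c1Cl`: 7.3 ug/mL

In a functional assay on A-431 cells (Homo sapiens) for cytotoxicity, read by MTT assay (on this read-out lower numbers stand for stronger inhibition and higher numbers for weaker inhibition), compound 1 gives 1.5 ug/mL. Compound 2 differs by fluoro in place of chloro on an aromatic carbon and gives 105 ug/mL, so a 70-fold higher number from compound 1 to compound 2 (1.85 log units; beyond the scatter). Compound 3 differs from compound 1 by diethylamino in place of fluoro on an aromatic carbon. Compound 3 gives 7.3 ug/mL, so a 4.9-fold higher number from compound 1 to compound 3 (0.69 log units; beyond the scatter).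

Compound 4 `CCN(CC)c1c(C#N)c(F)c2c(N)nc(N)nc2c1F` is not yet measured. It differs from compound 3 by fluoro in place of chloro on an aromatic carbon, the same kind of change as from compound 1 to compound 2, though around the place the surroundings differ: in compound 1 the carbon is ortho to a fluoro group, in compound 3 it is ortho to a diethylamino group.

For the measured compounds named here, for compound 4 a large step is expected in this assay, a 41-fold higher number from compound 3 to compound 4 (1.61 log units; beyond the scatter), because the only comparable change gave a 70-fold higher number from compound 1 to compound 2 (1.85 log units; beyond the scatter). Going by the values given here, the estimate for compound 4 is therefore 300 ug/mL, between 50 ug/mL and 1500 ug/mL; the different surroundings of the place, and only one prior example, leave this uncertain.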

Compound 4, half-maximal inhibitory concentration: 16.4 ug/mL
Beside the measured number, compound 4's estimate is 18-fold (1.26 log units) above it; the whole stated range lies above it.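

In this assay fluoro in place of chloro gives a 2.2-fold higher number from compound 3 to compound 4 (0.35 log units; beyond the scatter) on the diethylamino core, and this step does not match the one on the core of compound 1: the same change on two cores in this assay, a 70-fold higher number (1.85 log units; beyond the scatter) from compound 1 to compound 2 and a 2.2-fold higher number (0.35 log units; beyond the scatter) from compound 3 to compound 4, 31-fold (1.49 log units) apart, beyond the scatter of two such steps. Diethylamino in place of fluoro gives a 6.4-fold lower number from compound 2 to compound 4 (0.81 log units; beyond the scatter) when no chloro is present, opposite in direction to the step with chloro present: the same change on two cores in this assay, a 4.9-fold higher number (0.69 log units; beyond the scatter) from compound 1 to compound 3 and a 6.4-fold lower number (0.81 log units; beyond the scatter) from compound 2 to compound 4, 31-fold (1.49 log units) apart, beyond the scatter of two such steps. The size of the chloro change therefore does not carry from one core to another, although compound 1 and compound 3, the chloro members, keep the lower number in both pairs, and two pairs cannot show what sets the difference.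

Open, as far as these compounds go, is how bromo or methyl on that aromatic carbon would behave. Also open, from the compounds shown here alone, is whether a smaller amine, such as dimethylamino, or a cyclic amine, such as morpholine, would behave like diethylamino.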